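Swapping an anilino chain end for an ethoxycarbonyl group

This account rests on a few compounds, and the source may have more. Where it says the series, first, only, none or still open, it means among the compounds named here.

Measured so far in an assay on HEK293 cells for displacement of a labelled ligand from prostaglandin D2 receptor 2 (Homo sapiens); a lower number here means a stronger inhibitor, a higher number a weaker inhibitor:
- compound 1 `O=C(O)Cn1c(SCCOc2ccc3ccccc3c2)nc2ccccc21`: 2500 nM
- compound 2 `O=C(O)Cn1c(SCCOc2cccc3ccccc23)nc2ccccc21`: 2000 nM
- compound 3 `O=C(O)Cn1c(SCCCNc2ccccc2)nc2ccccc21`: 2690 nM

All three compounds share one core carrying an acetic acid and a sulfur-linked chain, and they differ only in what that chain ends in. Compound 3 gives the highest of the three numbers, but its gaps to compound 1 and to compound 2 lie within the usual scatter, so the three stand level and no order among them can be read.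

Compound 4 `CCOC(=O)CCCSc1nc2ccccc2n1CC(=O)O` takes the step from compound 3 with the change (ethoxycarbonyl in place of anilino on a saturated chain carbon, three bonds along the chain from a sulfur). What leaves carries the one six-membered aromatic ring of carbon only and the single hydrogen-bond donor; what enters is a short chain with no ring and two acceptors. Among the compounds with values here, every measured compound here carries an aromatic ring at the chain end, and compound 4 is the first without one, so the three measured values give no direct guide. The expectation is a moderate loss, a 2.2-fold higher number from compound 3 to compound 4 (0.35 log units; beyond the scatter), with wide uncertainty. Compound 4 is estimated at 6000 nM, within a range of 2000 nM to 20000 nM in this assay.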

Compound 4, half-maximal inhibitory concentration: 4410 nM
Estimate against measurement, compound 4: 1.4-fold (0.13 log units) above; measured number inside the range.
By their numbers in this assay, from the lowest: compounds 2, 1, 3 and 4 (each within the scatter of the next, the first and the last beyond it).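

In this assay, putting ethoxycarbonyl in place of anilino on a saturated chain carbon, three bonds along the chain from a sulfur, gives a 1.6-fold higher number from compound 3 to compound 4 (0.21 log units; within the scatter) and so cannot be told apart from no change at all. For this one pair, the chain end can therefore lose its six-membered aromatic ring of carbon only and its hydrogen-bond donor, and gain a short chain with no ring, without a change in the number that can be read. No measurement shown here explains this result.

As far as these compounds go, it remains open whether a carboxylic acid or an amide in place of ethoxycarbonyl would give a step beyond the usual scatter. A phenoxy group at the same place, or a longer chain carrying ethoxycarbonyl, is equally untested among the compounds shown.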